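Chloro for Hydrogen on the Anilide of Compound 3

A few compounds are considered here, and "the series" means these few. Any claim that something is new, unique, unknown or untested is made for them only; others in the source may bear on it.

The series is read in a functional assay on CNE cells (Homo sapiens) for cytotoxicity, read by MTT assay, with a stated time of 72 h; a lower number here means a stronger inhibitor, a higher number a weaker inhibitor. Compound 1 `COc1ccc(NC(=O)COC(=O)/C=C/c2cc(OC)c(OCc3ccc(Cl)c(Cl)c3)c(OC)c2)cc1` gives only a limit there, > 200000 nM. Compound 2 `CCOc1ccc(COc2c(OC)cc(/C=C/C(=O)N3CCN(Cc4ccc(Cl)c(Cl)c4)CC3)cc2OC)cc1` likewise returns only a limit, > 200000 nM. Compound 3 `COc1ccc(/C=C/C(=O)OCC(=O)Nc2ccccc2)cc1OC` also returns only a limit, > 200000 nM. All three measured values thus sit at the limit of > 200000 nM in this assay, at which 3 of the 3 values shown sit, and none of them is a number. Compound 3 therefore stands nowhere within a measured range, and no order among compounds 1, 2 and 3 can be drawn from this assay.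

Compound 4 `COc1ccc(/C=C/C(=O)OCC(=O)Nc2ccc(Cl)cc2)cc1OC` is the next member, not yet measured. It differs from compound 3 by chloro in place of hydrogen on an aromatic carbon. Among the measured compounds shown here, no step between measured compounds exists to calibrate this change, and no numbered anchor is available because compound 3 gives only > 200000 nM. The expected step is a step that the limit leaves unreadable from compound 3 to compound 4, none beyond the scatter, in no direction. Compound 4 is accordingly estimated at 300000 nM, within 100000 nM to 1000000 nM, and most probably reported again only as a limit in this assay.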

Compound 4, half-maximal inhibitory concentration: > 200000 nM
Compound 4: no number, only a limit; the forecaster's own chance of this, stated with the estimate: 80%; the middle value lies beyond the limit too.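

Compound 4, like compound 3, gives only a limit and not a number, so no step can be read between them in this assay: the limit of > 200000 nM in this assay, at which 4 of the 4 values shown sit.

The compounds shown leave open whether chloro in place of hydrogen on an aromatic carbon changes cytotoxicity at all, and how the four compounds would rank.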